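Amino to Methyl on a Dichloroacetamide Biaryl

The compounds below may be only part of what the source reports. "The series", "measured", "known", "first", "only" and "open" are said of these compounds alone.

Three dichloroacetamides have been measured. Compound 1 `O=C(Nc1cccc(-c2ccsc2)c1)C(Cl)Cl` carries a thiophen-3-yl group on its aniline ring, compound 2 `O=C(Nc1cccc(-c2nccs2)c1)C(Cl)Cl` a 1,3-thiazol-2-yl group in the same position, and compound 3 `Nc1cccc(-c2cccc(NC(=O)C(Cl)Cl)c2)c1` a second benzene ring bearing an amino group. In a functional assay on NCI-H460 cells (Homo sapiens) for cytotoxicity, read by MTT assay, with a stated time of 68 h (a higher number here means a weaker inhibitor, a lower number a stronger inhibitor), compound 1 gives only a limit, > 50000 nM. In this assay compound 2 likewise gives only a limit, > 50000 nM. Compound 3 too gives only a limit, > 50000 nM. Among the compounds with values here, the single step between compounds that differ in one place, a step that the two limits leave unreadable from compound 1 to compound 2, cannot be read, since both ends are limits. Compound 3 thus stands where every measured compound stands: the limit of > 50000 nM in this assay, at which 3 of the 3 values shown sit.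

Compound 4 `Cc1cccc(-c2cccc(NC(=O)C(Cl)Cl)c2)c1` differs from compound 3 in one place: methyl in place of amino on an aromatic carbon.

Within the data shown here, no measured step bears on this change; the only step available is unreadable, and no number sits below the limit that could set a direction. The expectation therefore rests on the limit alone. Compound 4 is expected to give 80000 nM, with a range from 30000 nM to 200000 nM, most probably reported again as a limit. The expected step that the limit leaves unreadable from compound 3 to compound 4 is accordingly estimated as none beyond the scatter.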

Compound 4, half-maximal inhibitory concentration: 24300 nM
Beside the measured number, compound 4's estimate is 3.3-fold (0.52 log units) above it, and the stated range ends above it.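

In this assay, methyl in place of amino on an aromatic carbon, meta to a large group, brings an at least 2.0-fold lower number from compound 3 to compound 4 (0.31 log units; beyond the scatter). Within the data shown here, this is the first sign that a change at this position can move the series to a readable number, and the step has a stated minimum only, since one end of it is a limit. Compound 4 stands apart as the only compound shown with a number rather than a limit: the limit of > 50000 nM in this assay, at which 3 of the 4 values shown sit. 

This single pair cannot say which difference between the groups matters, whether the loss of amino, with its 1 hydrogen-bond donor and 1 hydrogen-bond acceptor, or the arrival of methyl, which has 0 of each. As far as these compounds go, it remains open whether an ethyl group, a methoxy group, a chlorine atom or a hydroxyl group at the same position would give a number like that of compound 4, and whether a longer chain would carry the change further.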